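Chloro in Place of Acetoxy on a Weak Side Chain

The source may report more compounds than this note shows. Statements on the series, on what has been measured and on what is new or still open speak of the compounds shown alone.

Compound 1 `CC(=O)OCCc1c(C)[nH]c(=O)[nH]c1=O`: > 100000 nM, a limit of the assay
Compound 2 `COc1nc(Cl)nc(C)c1CCO`: > 100000 nM, a limit of the assay
Compound 3 `COc1nc(C)c(CCOC(C)=O)c(OC)n1`: 40000 nM

All three were tested in a functional assay on HCT-116 cells (Homo sapiens) for antiproliferative activity, read by MTT assay, with a stated time of 24 h; a higher number here means a weaker inhibitor, a lower number a stronger inhibitor. For compound 1 only a limit is known, > 100000 nM, and one other compound shares that limit (the limit of > 100000 nM in this assay, at which 2 of the 3 values shown sit). Compound 4 `Cc1[nH]c(=O)[nH]c(=O)c1CCCl` differs from compound 1 by chloro in place of acetoxy on a saturated chain carbon, two bonds along the chain from an aromatic carbon. For the measured compounds named here, no comparable step between measured compounds is known, so the change itself gives no guide. With compound 1 at a limit in this assay, the expected step of a number no higher from compound 1 to compound 4 (the limit leaves the size open) is none beyond the scatter. Compound 4 is therefore estimated at 100000 nM in this assay, within 30000 nM to 300000 nM, most likely again reported only as a limit.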

Compound 4, half-maximal inhibitory concentration: > 100000 nM
Compound 4: no number, only a limit; the forecaster's own chance of this, stated with the estimate: 70%; the middle value sits exactly at the limit.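

No step can be read between compound 1 and compound 4, because each gives only a limit: the limit of > 100000 nM in this assay, at which 3 of the 4 values shown sit.

The compounds shown leave open whether chloro in place of acetoxy changes antiproliferative activity at all.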